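The source may hold more compounds than are shown below. What is called first, only, known or untested is meant among the compounds shown, and "the series" means these compounds.

Measured in a functional assay on T-24 cells (Homo sapiens) for inhibition, read by MTT assay, with a stated time of 3 days; on this read-out higher numbers stand for weaker inhibition of growth and lower numbers for stronger inhibition of growth:
Compound 1 `COc1ccc(C(=O)NC(=O)c2cc3cc(OC)ccc3s2)c(OC)c1`: > 15000 nM (a limit)
Compound 2 `COc1ccc2sc(C(=O)NC(=O)c3ccc(F)cc3OC)cc2c1`: > 15000 nM (a limit)
Compound 3 `CCOc1ccccc1C(=O)NC(=O)c1cc2cc(OC)ccc2s1`: < 100 nM (a limit)

On the numbers shown, compound 3 stands alone at the low limit in this assay, with no exact value. Compound 4 `COc1ccc2sc(C(=O)NC(=O)c3ccccc3OC(F)(F)F)cc2c1` differs from it in one place: trifluoromethyl in place of ethyl on an oxygen on an aromatic ring, that is, ethoxy to trifluoromethoxy. Among the measured compounds shown here, the only measured step, a step that the two limits leave unreadable from compound 1 to compound 2, is a different exchange and offers no size to carry over. The expectation is therefore a loose judgement, leaning toward weaker inhibition of growth. The estimated change is an at least 4.0-fold higher number from compound 3 to compound 4 (0.60 log units; beyond the scatter), with wide uncertainty. Compound 4 is expected at 400 nM, with an estimated range from 40 nM to 8000 nM.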

Compound 4, concentration for 50% growth inhibition: 1100 nM
Estimate against measurement, compound 4: 2.8-fold (0.44 log units) below; low and high end bracket the measured number.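

In this assay, among the compounds shown here, putting trifluoromethyl in place of ethyl on an oxygen on an aromatic ring gives an at least 11-fold higher number from compound 3 to compound 4 (1.04 log units; beyond the scatter), the first readable step, and it shows that inhibition of growth responds strongly to what sits on this oxygen. Compound 3 is held only by a limit, so this step gives a minimum and not a full size: the limit of < 100 nM in this assay, at which 1 of the 4 values shown sits.

The compounds shown leave open the cause of this step. They also leave open where a propyl chain or a difluoromethyl on the same oxygen would fall.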